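Swapping the aryl halide on a hydrazone side chain

This account rests on a few compounds, and the source may have more. Where it says the series, first, only, none or still open, it means among the compounds named here.

Measured compounds:
- compound 1, `Cn1c(=O)c(=O)n(C2CCCC2)c2nc(N/N=C/c3ccc(Cl)cc3)ncc21`: 8420 nM
- compound 2, `Cn1c(=O)c(=O)n(C2CCCC2)c2nc(N/N=C/c3ccc(C(F)(F)F)cc3)ncc21`: 23600 nM
- compound 3, `COc1ccc(/C=N/Nc2ncc3c(n2)n(C2CCCC2)c(=O)c(=O)n3C)cc1`: 26300 nM

In a functional assay on PC-3 cells (Homo sapiens) for antiproliferative activity, read by MTT assay (on this read-out higher numbers stand for weaker inhibition and lower numbers for stronger inhibition), compound 1 gives the lowest number of the three, with compound 2 and compound 3 sitting higher. Both known changes start from compound 1 and touch the same aromatic carbon: trifluoromethyl in place of chloro gives a 2.8-fold higher number from compound 1 to compound 2 (0.45 log units; beyond the scatter), and methoxy in place of chloro gives a 3.1-fold higher number from compound 1 to compound 3 (0.49 log units; beyond the scatter). Between the two replacements themselves the gap is a 1.1-fold higher number from compound 2 to compound 3 (0.05 log units; within the scatter).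

Compound 4, `Cn1c(=O)c(=O)n(C2CCCC2)c2nc(N/N=C/c3ccccc3F)ncc21`, is not yet measured. It differs from compound 1 by 2-fluorophenyl in place of 4-chlorophenyl on a carbon with a double bond to nitrogen. Among the measured compounds shown here, no measured pair tests this exact change, since here both the halogen and the ring carbon that carries it move at once. What the measured steps do show is that every departure from chloro so far has raised the number in this assay by a modest amount. A similar modest rise is therefore the expectation for compound 4, though with wide uncertainty because only a 2.8-fold higher number from compound 1 to compound 2 (0.45 log units; beyond the scatter) and a 3.1-fold higher number from compound 1 to compound 3 (0.49 log units; beyond the scatter) inform it. Compound 4 is estimated at 16000 nM, within 6000 nM to 45000 nM, which corresponds to an expected step of a 1.9-fold higher number from compound 1 to compound 4 (0.28 log units; within the scatter).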

Compound 4, half-maximal inhibitory concentration: 27600 nM
Estimate against measurement, compound 4: 1.7-fold (0.24 log units) below; low and high end bracket the measured number.
By their numbers in this assay, from the lowest: compound 1; then compounds 2, 3 and 4 (each within the scatter of the next).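

In this assay, among the compounds shown here, 2-fluorophenyl in place of 4-chlorophenyl also costs activity (a 3.3-fold higher number from compound 1 to compound 4 (0.52 log units; beyond the scatter)), so this change joins the two earlier replacements, and compound 1 remains the only compound of the four set apart from the rest. What compound 4 adds is that a ring with a different halogen on a different carbon cannot be told apart from the other two replacements (a 1.0-fold higher number from compound 3 to compound 4 (0.02 log units; within the scatter); a 1.2-fold higher number from compound 2 to compound 4 (0.07 log units; within the scatter)), so the 4-chlorophenyl group of compound 1 is the one that stands out among these four rings, not any of the groups that replace it. Why these three different rings give such similar numbers cannot be said, as no supporting measurement bears on the cause here.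

The shown compounds do not separate the change of halogen from the change of ring carbon, as compound 4 differs from compound 1 in both at once. Also open, from the compounds shown here alone, is how this place would respond to a ring carrying an amine or a carboxylic acid, or to a plain unsubstituted phenyl ring.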